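Cytotoxicity Across Benzyl Ether Variants of a Shared Core

A few compounds are considered here, and "the series" means these few. Any claim that something is new, unique, unknown or untested is made for them only; others in the source may bear on it.

Compound 3 `CCC1(Cc2ccccc2)OS(=O)(=O)C=C1OCc1cccc(Cl)c1` carries a 3-chlorophenyl on a saturated chain carbon bound to an oxygen on an unsaturated carbon, and in an ADME assay on HEL cells (Homo sapiens) for cytotoxicity, with a stated time of 3 days (a lower number here means that less compound is tolerated, a higher number that more compound is tolerated), compound 3 gives 50000 nM. Among the compounds with values here, of the two numbers known, this is the highest, but its nearest neighbour compound 2 `CCC1(Cc2ccccc2)OS(=O)(=O)C=C1OCc1ccccc1Cl` gives 38000 nM in this assay, and the step of a 1.3-fold higher number from compound 2 to compound 3 (0.12 log units; within the scatter) stays within the scatter. Compound 1 `CCC1(Cc2ccccc2)OS(=O)(=O)C=C1OCC#N` gives only a limit in this assay, > 200000 nM, as noted in the limit of > 200000 nM in this assay, at which 1 of the 3 values shown sits. The two steps from that limit, an at least 5.2-fold lower number from compound 1 to compound 2 (0.72 log units; beyond the scatter) and an at least 4.0-fold lower number from compound 1 to compound 3 (0.60 log units; beyond the scatter), are the only ones beyond the scatter, and both follow the entry of a chloro-substituted phenyl in place of cyano.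

Compound 4 `CCC1(Cc2ccccc2)OS(=O)(=O)C=C1OCc1ccc(C)cc1` is not yet measured. Its difference from compound 3 is 4-methylphenyl in place of 3-chlorophenyl on a saturated chain carbon bound to an oxygen on an unsaturated carbon. Since moving the chlorine between two ring positions gave no step beyond the scatter, one aryl replacing another is expected to give a step of no change at the digits printed from compound 3 to compound 4 (within the scatter) in this assay, none beyond the scatter. Compound 4 is therefore estimated at 50000 nM, within 22000 nM to 110000 nM.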

Compound 4, half-maximal cytotoxic concentration: 41500 nM
Estimate against measurement, compound 4: 1.2-fold (0.08 log units) above; the measured number falls inside the stated range.
By their numbers in this assay, from the lowest: compounds 2, 4 and 3 (each within the scatter of the next). At a limit, above all of these: compound 1.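

In this assay the place on a saturated chain carbon bound to an oxygen on an unsaturated carbon accepts 4-methylphenyl as readily as either chlorophenyl, as a 1.2-fold lower number from compound 3 to compound 4 (0.08 log units; within the scatter) and a 1.1-fold higher number from compound 2 to compound 4 (0.04 log units; within the scatter) show. Chlorine on the ring is therefore not required for a number in this range, and the three aryl groups cannot be told apart here. The step away from cyano, seen in an at least 4.8-fold lower number from compound 1 to compound 4 (0.68 log units; beyond the scatter), now also holds for a ring without chlorine, though it is read against a limit for compound 1: the limit of > 200000 nM in this assay, at which 1 of the 4 values shown sits.

On these data alone, it remains open whether an aryl ring bearing an amine or a carboxylic acid would leave the number in this range. Also open, as far as these compounds go, is whether a plain alkyl chain in place of the aryl group would behave like cyano or like the aryl groups.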